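A few compounds are considered here, and "the series" means these few. Any claim that something is new, unique, unknown or untested is made for them only; others in the source may bear on it.

Series notes. Compound 3 `CNC(=O)c1cc(Oc2cccc(NC(=S)Nc3cccc(C(F)(F)F)c3)c2)ccn1` is the reference point for the step considered here. In a functional assay on MDA-MB-231 cells (Homo sapiens) for cytotoxicity, read by MTT assay, with a stated time of 48 h (on this read-out lower numbers stand for stronger inhibition and higher numbers for weaker inhibition), compound 3 gives > 100000 nM, which is a limit of the assay and not a number. Compound 1 `CNC(=O)c1cc(Oc2cccc(NC(=S)Nc3ccc(Cl)cc3)c2)ccn1` carries 4-chlorophenyl on an amide-type nitrogen where compound 3 carries 3-(trifluoromethyl)phenyl. In this assay compound 1 gives > 100000 nM, again a limit. The step that the two limits leave unreadable from compound 1 to compound 3 is therefore of unreadable size. Compound 2 `CCNC(=O)c1cc(Oc2cccc(NC(=S)Nc3ccc(F)c(F)c3)c2)ccn1` already carries the ethylcarbamoyl group together with a 3,4-difluorophenyl ring. In this assay compound 2 gives > 100000 nM, also a limit. All three measured values thus sit at the limit of > 100000 nM in this assay, at which 3 of the 3 values shown sit, and compound 3 stands at that limit with no ordering possible among the three.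

Compound 4 `CCNC(=O)c1cc(Oc2cccc(NC(=S)Nc3cccc(C(F)(F)F)c3)c2)ccn1` differs from compound 3 by methyl in place of hydrogen on a saturated chain carbon bound to an amide-type nitrogen, read one bond further out as methylcarbamoyl to ethylcarbamoyl. Within the data shown here, no measured step bears directly on this change. Among the measured compounds shown here, the only measured step, a step that the two limits leave unreadable from compound 1 to compound 3, is unreadable, and compound 2, which carries the ethylcarbamoyl group, also sits at the limit. Compound 4 is therefore expected to remain at the limit in this assay, with the step that the limit leaves unreadable from compound 3 to compound 4 expected to be none beyond the scatter in any readable sense. Compound 4 is estimated at 150000 nM, within 50000 nM to 500000 nM.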

Compound 4, half-maximal inhibitory concentration: 53100 nM
Estimate against measurement, compound 4: 2.8-fold (0.45 log units) above; the measured number falls inside the stated range.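

In this assay compound 4 gives 53100 nM, which makes it the one compound shown with a number and not a limit, and so the one readable point at this position. Methyl in place of hydrogen on the saturated chain carbon bound to an amide-type nitrogen gives an at least 1.8-fold lower number from compound 3 to compound 4 (0.27 log units; that floor lies within the scatter), and 3-(trifluoromethyl)phenyl in place of 3,4-difluorophenyl on an amide-type nitrogen gives an at least 1.8-fold lower number from compound 2 to compound 4 (0.27 log units; that floor lies within the scatter). These steps give a direction for both changes, but only as floors, and the steps among the remaining compounds cannot be read, the other values all being limits: the limit of > 100000 nM in this assay, at which 3 of the 4 values shown sit.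

Still open, on these data alone, is how the number responds to a propyl chain or a cyclopropyl group in place of the ethyl on the amide-type nitrogen, since the series stops at ethylcarbamoyl. Also open, as far as these compounds go, is whether the ethylcarbamoyl group gives a number when paired with the 4-chlorophenyl ring of compound 1, which would show whether the readable value depends on the 3-(trifluoromethyl)phenyl ring.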